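The source may report more compounds than this note shows. Statements on the series, on what has been measured and on what is new or still open speak of the compounds shown alone.

In a functional assay on A-431 cells (Homo sapiens) for inhibition, with a stated time of 72 h (a lower number here means a stronger inhibitor, a higher number a weaker inhibitor), compound 1 (`CCN(CC)Cc1ccc2cccnc2c1O`) gives 13500 nM, compound 2 (`Oc1c(CN2CCCC2)ccc2cccnc12`) gives 16600 nM and compound 3 (`Oc1c(CN2CCCCC2)ccc2cccnc12`) gives 9770 nM, so compound 1 stands among values that cannot be told apart. Compound 4 (`CCN(CC)Cc1cc(Cl)c2cccnc2c1O`) keeps the (diethylamino)methyl group of compound 1 and carries chloro in place of hydrogen on an aromatic carbon, para to a hydroxy group: chloro in place of hydrogen on an aromatic carbon. The measured steps, a 1.2-fold higher number from compound 1 to compound 2 (0.09 log units; within the scatter), a 1.4-fold lower number from compound 1 to compound 3 (0.14 log units; within the scatter) and a 1.7-fold lower number from compound 2 to compound 3 (0.23 log units; within the scatter), all exchange the amino group on the saturated chain carbon, and none touches this aromatic carbon. They give no direct size for the new change, so only a modest, uncertain lowering is expected in this assay. The expected step is a 2.1-fold lower number from compound 1 to compound 4 (0.32 log units; beyond the scatter). For compound 4 the estimate is 6500 nM, with an expected range of 2500 nM to 14000 nM.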

Compound 4, half-maximal inhibitory concentration: 9330 nM
For compound 4 the middle estimate is 1.4-fold (0.16 log units) below the measured one, within the range that was stated.
By their numbers in this assay, from the lowest: compounds 4, 3, 1 and 2 (each within the scatter of the next).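

With chloro in place of hydrogen on the aromatic carbon para to a hydroxy group, this assay shows a 1.4-fold lower number from compound 1 to compound 4 (0.16 log units; within the scatter). Within the data shown here, this is the first reading at this carbon, which the amino group exchanges left untouched, and here a chlorine brings a step no larger than the scatter. Nothing on hand accounts for this result.
Going by these compounds, whether bromo or methoxy on this aromatic carbon would give a step beyond the scatter stays open. So does how chloro behaves with pyrrolidin-1-yl or piperidin-1-yl in place of diethylamino.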